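The source may hold more compounds than are shown below. What is called first, only, known or untested is meant among the compounds shown, and "the series" means these compounds.

Measured in a functional assay on HepG2 cells (Homo sapiens) for antiproliferative activity, read by MTT assay, with a stated time of 48 h; on this read-out higher numbers stand for weaker inhibition and lower numbers for stronger inhibition:
- compound 1 `COc1ccc(/C=C/c2cc(OC)cc(OC)c2/C=C/C(=O)c2ccc(C(F)(F)F)cc2)cc1`: 18.7 ug/mL
- compound 2 `COc1ccc(/C=C/c2cc(OC)cc(OC)c2/C=C/C(=O)c2ccc(F)cc2)cc1`: 12.2 ug/mL
- compound 3 `COc1ccc(/C=C/c2cc(OC)cc(OC)c2/C=C/C(=O)c2ccccc2C)cc1`: 5.3 ug/mL

Of these three, compound 3 gives the lowest number in this assay, at 5.3 ug/mL. The next structure, compound 4 `CCN(CC)c1ccc(C(=O)/C=C/c2c(/C=C/c3ccc(OC)cc3)cc(OC)cc2OC)cc1`, keeps the shared core and changes only the group on the carbonyl carbon: 4-(diethylamino)phenyl in place of 2-methylphenyl on a carbonyl carbon. In words, 4-(diethylamino)phenyl stands in place of 2-methylphenyl.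

Two measured steps change the group at this same place, a 3.5-fold lower number from compound 1 to compound 3 (0.55 log units; beyond the scatter) and a 2.3-fold lower number from compound 2 to compound 3 (0.36 log units; beyond the scatter). Both are modest, and both arrive at 2-methylphenyl with a lower number. Compound 4 gives up that group, so a modest move toward a higher number is expected. For the measured compounds named here, no measured compound carries 4-(diethylamino)phenyl, however, so the size of the move remains uncertain, and the range is kept wide. The expected change is a 2.1-fold higher number from compound 3 to compound 4 (0.32 log units; beyond the scatter). For compound 4 the estimated value is 11 ug/mL, with an expected range of 4.5 ug/mL to 26 ug/mL.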

Compound 4, half-maximal inhibitory concentration: 6.3 ug/mL
Compound 4: the middle estimate sits 1.7-fold (0.24 log units) above what was measured, within the range that was stated.
By their numbers in this assay, from the lowest: compounds 3, 4, 2 and 1 (each within the scatter of the next, the first and the last beyond it).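

In this assay, the place on the carbonyl carbon accepts the larger, nitrogen-bearing 4-(diethylamino)phenyl: with a 1.2-fold higher number from compound 3 to compound 4 (0.08 log units; within the scatter), 2-methylphenyl no longer stands alone among the compounds shown at the low end of the numbers. The same exchange of diethylamino for fluoro gives a 1.9-fold lower number from compound 2 to compound 4 (0.29 log units; within the scatter), whereas the exchange for trifluoromethyl gives a 3.0-fold lower number from compound 1 to compound 4 (0.47 log units; beyond the scatter), so among these two steps only the one from the trifluoromethyl compound is clearly resolved. Nothing available here bears on what lies behind these results.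

The compounds shown leave open whether a dimethylamino group or a carboxylic acid in place of diethylamino would give a similar number. They also leave open whether a cyclohexyl group on the carbonyl carbon, with no aromatic ring, would do so.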